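One stereocentre left undrawn in a potent compound

This account rests on a few compounds, and the source may have more. Where it says the series, first, only, none or still open, it means among the compounds named here.

- compound 1 `Cc1c(Cl)ccc2c1NC(=O)C2(c1ccc(O)cc1)C1CCCCCC1` (150 nM)
- compound 2 `COc1ccc2c(c1C)NC(=O)[C@]2(c1ccc(O)cc1)C1CCCCCC1` (2 nM)

In a functional assay on PC-3 cells (Homo sapiens) for cytotoxicity, read by WST assay, with a stated time of 72 h (a lower number here means a stronger inhibitor, a higher number a weaker inhibitor), compound 2 stands lowest of the two (2 nM), while compound 1 reads higher (150 nM), a gap beyond the scatter. Compound 3 `COc1ccc2c(c1C)NC(=O)C2(c1ccc(O)cc1)C1CCCCCC1` has the same atoms and bonds as compound 2 (the two compounds have the same atoms and bonds; at least one stereo element is drawn with a configuration in one of them and without one in the other: 1 of 1 stereo elements differ; a stereocentre at a saturated ring carbon is drawn S in compound 2 and without a configuration in compound 3): a stereocentre at a saturated ring carbon is drawn S in compound 2 and without a configuration in compound 3. The expected step of a 2.0-fold higher number from compound 2 to compound 3 (0.30 log units; within the scatter) is small, towards a higher number, and may stay within the scatter. The estimate for compound 3 in this assay is 4 nM (expected range 2 nM to 10 nM).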

Compound 3, half-maximal inhibitory concentration: 12 nM
Beside the measured number, compound 3's estimate is 3.0-fold (0.48 log units) below it; the whole stated range lies below it.
By their numbers in this assay, from the lowest: compound 2; then compound 3; then compound 1.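

In this assay, for the compounds shown here, how this stereocentre is drawn goes with a step beyond the scatter, a 6.0-fold higher number from compound 2 to compound 3 (0.78 log units; beyond the scatter), and only one thing separates the pair: the fact that one of compounds 2 and 3 is drawn with a defined configuration and the other without, at the place where they differ. With the centre undrawn on both sides, methoxy in place of chloro on an aromatic carbon gives a 13-fold lower number from compound 1 to compound 3 (1.10 log units; beyond the scatter), so that swap can now be read without the stereo difference.

Open, as far as these compounds go, is what the centre drawn R would read, and whether compound 3 holds both configurations. Also open, from the compounds shown here alone, is how an ethoxy group or an amine would read in place of the methoxy.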